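This account rests on a few compounds, and the source may have more. Where it says the series, first, only, none or still open, it means among the compounds named here.

Measured so far:
Compound 1, `COc1ncnc2c1c(I)cn2[C@@H]1O[C@H](CO)[C@@H](O)[C@H]1O`: 2300 nM
Compound 2, `COc1ncnc2c1c(-c1cc3ccccc3o1)cn2[C@@H]1O[C@H](CO)[C@@H](O)[C@H]1O`: 4470 nM

In a functional assay on HL-60 cells (Homo sapiens) for antiproliferative activity, read by XTT assay, with a stated time of 72 h (on this read-out higher numbers stand for weaker inhibition and lower numbers for stronger inhibition), compound 2 gives 4470 nM, the higher of the two numbers shown; its nearest neighbour is compound 1, and the step of a 1.9-fold higher number from compound 1 to compound 2 (0.29 log units; within the scatter) is within the scatter. Compound 3, `COc1ncnc2c1c(-c1ccco1)cn2[C@@H]1O[C@H](CO)[C@@H](O)[C@H]1O`, differs from compound 2 by furan-2-yl in place of 1-benzofuran-2-yl on an aromatic carbon. Among the measured compounds shown here, the only measured step at this place, a 1.9-fold higher number from compound 1 to compound 2 (0.29 log units; within the scatter), was within the scatter, so the expected step of a 1.3-fold lower number from compound 2 to compound 3 (0.11 log units; within the scatter) is none beyond the scatter. Compound 3 is therefore estimated at 3500 nM, with a range from 1200 nM to 10000 nM.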

Compound 3, half-maximal inhibitory concentration: 100 nM
Compound 3: middle estimate off by 35-fold (1.54 log units), on the high side, outside the stated range (below it).
By their numbers in this assay, from the lowest: compound 3; then compounds 1 and 2 (each within the scatter of the next).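

In this assay, among the compounds shown here, this carbon of the five-membered ring proves sensitive to the group it carries: furan-2-yl gives a 45-fold lower number from compound 2 to compound 3 (1.65 log units; beyond the scatter) and a 23-fold lower number from compound 1 to compound 3 (1.36 log units; beyond the scatter), whereas the one earlier step here stayed within the scatter. Compound 3 differs from compound 2 by losing the six-membered aromatic ring of 1-benzofuran-2-yl. No measurement available here explains this stronger inhibition. Still open, from the compounds shown here alone, is whether the effect is particular to furan-2-yl, or whether a thiophen-2-yl group or an amine on this carbon would match it.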